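Fluoro for methoxymethoxy: a small step expected

This account rests on a few compounds, and the source may have more. Where it says the series, first, only, none or still open, it means among the compounds named here.

In a functional assay on HL-60 cells (Homo sapiens) for cytotoxicity, read by WST assay, with a stated time of 48 h (a lower number here means that less compound is needed, a higher number that more compound is needed for the effect), compound 1 `O=C1OC[C@H](Cc2ccccc2)[C@H]1Cc1ccccc1F` gives 72000 nM and compound 2 `O=C1OC[C@H](Cc2ccccc2)[C@H]1Cc1cccc(Cl)c1` gives 36000 nM. Within the data shown here, the only measured step between compounds that differ in one place is a 2.0-fold lower number from compound 1 to compound 2 (0.30 log units; within the scatter), with one halogen-bearing phenyl replacing another. Compound 3 `COCOc1ccc(C[C@H]2C(=O)OC[C@@H]2Cc2ccccc2)cc1` gives 71000 nM, which lies within the usual scatter of both other values, so the three compounds stand level on these numbers.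

Compound 4 `O=C1OC[C@H](Cc2ccccc2)[C@H]1Cc1ccc(F)cc1` keeps the shared core but has fluoro in place of methoxymethoxy on an aromatic carbon, para to a large group: fluoro in place of methoxymethoxy on an aromatic carbon. Among the measured compounds shown here, no measured step makes this exact change, so the evidence is indirect. For the measured compounds named here, the single measured step stays within the scatter, and compound 3, with its methoxymethoxy group, sits at 71000 nM, level with the halogen-bearing compound 1 at 72000 nM. Among these three compounds, none goes against the picture of a flat response to the change on the aromatic ring. No step beyond the scatter is therefore expected in this assay. The expected change is a 1.3-fold lower number from compound 3 to compound 4 (0.11 log units; within the scatter), which would lie within the scatter. Compound 4 is estimated at 55000 nM, with an expected range from 28000 nM to 105000 nM.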

Compound 4, half-maximal effective concentration: 57000 nM
Estimate against measurement, compound 4: 1.0-fold (0.02 log units) below; the measured number falls inside the stated range.
By their numbers in this assay, from the lowest: compounds 2, 4, 3 and 1 (each within the scatter of the next).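

In this assay, among these compounds, the methoxymethoxy group, with its four heavy atoms and two hydrogen-bond acceptors, gives way to a single fluoro with no acceptors, and the result is a 1.2-fold lower number from compound 3 to compound 4 (0.10 log units; within the scatter), so even this larger change in size and acceptor count on an aromatic carbon, para to a large group, produces no step that can be told from noise. The halogen-bearing compounds add to this: 4-fluorophenyl in place of 2-fluorophenyl gives a 1.3-fold lower number from compound 1 to compound 4 (0.10 log units; within the scatter), and 4-fluorophenyl in place of 3-chlorophenyl gives a 1.6-fold higher number from compound 2 to compound 4 (0.20 log units; within the scatter), so among these four compounds neither the kind of group nor the ring position of the halogen separates them. Nothing available explains why the numbers stay this level.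

On these data alone, it remains open whether an amine or a carboxylic acid on this ring carbon, or a longer chain there, would give a step beyond the scatter. The compounds shown also leave untested any group on the unsubstituted phenyl that all four share.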